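Changing the Ring on the Aromatic Nitrogen of Compound 2

The source may report more compounds than this note shows. Statements on the series, on what has been measured and on what is new or still open speak of the compounds shown alone.

Of the compounds shown here, two have been measured in an assay on HeLa cells for displacement of a labelled ligand from 5-hydroxytryptamine receptor 6 (Homo sapiens); on this read-out higher numbers stand for weaker inhibition and lower numbers for stronger inhibition. Compound 1 `O=S(=O)(c1cccc(F)c1)c1cn(C2CCNC2)c2ncccc12` gives 2.7 nM, and compound 2 `O=S(=O)(c1cccc(C(F)(F)F)c1)c1cn(C2CCNC2)c2ncccc12` gives 1.3 nM. Within the data shown here, the one measured step, a 2.1-fold lower number from compound 1 to compound 2 (0.32 log units; beyond the scatter), leaves compound 2 with the lowest of the two numbers, compound 1 being its nearest neighbour. Compound 3 `CN1CCCC(n2cc(S(=O)(=O)c3cccc(C(F)(F)F)c3)c3cccnc32)C1` differs from compound 2 by 1-methylpiperidin-3-yl in place of pyrrolidin-3-yl on an aromatic nitrogen. Among the measured compounds shown here, no measured step touches the group on that aromatic nitrogen; the only step known, a 2.1-fold lower number from compound 1 to compound 2 (0.32 log units; beyond the scatter), concerns a substituent on an aromatic carbon and does not bear directly on this change. Without a guide, a modest step in either direction, or none beyond the scatter, remains possible, so the estimate is kept close to compound 2 with a wide range. Compound 3 is expected to give 3 nM, between 0.8 nM and 12 nM. For compound 3 this means an expected step of a 2.3-fold higher number from compound 2 to compound 3 (0.36 log units; beyond the scatter).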

Compound 3, inhibition constant: 2.1 nM
Compound 3: middle estimate off by 1.4-fold (0.15 log units), on the high side; low and high end bracket the measured number.
By their numbers in this assay, from the lowest: compounds 2, 3 and 1 (each within the scatter of the next, the first and the last beyond it).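

In this assay, the only change shown on the aromatic nitrogen, 1-methylpiperidin-3-yl in place of pyrrolidin-3-yl, gives a 1.6-fold higher number from compound 2 to compound 3 (0.21 log units; within the scatter) and so does not separate the two compounds. This position therefore accepts a six-membered ring in place of a five-membered one, with more heavy atoms and without the hydrogen-bond donor of pyrrolidin-3-yl, and the number stays within the scatter. No measurement shown here offers an explanation for this result.

Ring size and the methyl group on the ring nitrogen change together, so the compounds shown leave their separate contributions open; 1-methylpyrrolidin-3-yl and unsubstituted piperidin-3-yl would divide the step. They also leave open how the read-out responds to an open-chain aminoethyl group on that nitrogen, with no ring at all.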